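The source may report more compounds than this note shows. Statements on the series, on what has been measured and on what is new or still open speak of the compounds shown alone.

Measured so far:
- Compound 1, `Cc1ccc(NC[C@@]2(C)C[C@@H](O)CC(C)(C)C2)cc1S(N)(=O)=O`: in an ADME assay on MDCK cells (Canis lupus familiaris) for cytotoxicity, read by MTT assay, with a stated time of 3 days (on this read-out higher numbers stand for lower toxicity in this test and lower numbers for higher toxicity in this test), compound 1 gives 81500 nM.
- Compound 2, `COc1ccc(NC[C@@]2(C)C[C@@H](O)CC(C)(C)C2)cc1S(N)(=O)=O`: in this assay compound 2 reaches only the limit of the assay, > 100000 nM.

Compound 2 therefore stands at the limit of this assay, (the limit of > 100000 nM in this assay, at which 1 of the 2 values shown sits), so only a range is known for it and no number. Going by the values given here, the one measured step, an at least 1.2-fold higher number from compound 1 to compound 2 (0.08 log units; that floor lies within the scatter), shows that compound 2 is not more toxic than compound 1 in this assay, and that step is itself only a floor.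

Compound 3, `CC1(C)C[C@H](O)C[C@](C)(CNc2ccc(Cl)c(S(N)(=O)=O)c2)C1`, differs from compound 2 by chloro in place of methoxy on an aromatic carbon. Among the compounds with values here, no measured pair shows this change; the only step at hand is the one from compound 1 to compound 2, which lay within the scatter and ended at the limit. Compound 3 is therefore expected to remain near the limit, with an estimated value of 85000 nM, between 35000 nM and 200000 nM. The step that this estimate implies, an at least 1.1-fold lower number from compound 2 to compound 3 (0.07 log units; that floor lies within the scatter), is expected to be no larger than the scatter.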

Compound 3, half-maximal cytotoxic concentration: 71200 nM
For compound 3 the middle estimate is 1.2-fold (0.08 log units) above the measured one; the range from low to high includes it.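

In this assay compound 3 gives 71200 nM, so the aromatic carbon ortho to a sulfamoyl group and para to a large group now carries two groups, methyl and chloro, that can be compared directly. That comparison gives a 1.1-fold lower number from compound 1 to compound 3 (0.06 log units; within the scatter) and so does not separate chloro from methyl at this position in this test. Chloro in place of methoxy gives an at least 1.4-fold lower number from compound 2 to compound 3 (0.14 log units; that floor lies within the scatter) as a step that is only a floor, and its true size stays unknown because compound 2 is read only as a limit: the limit of > 100000 nM in this assay, at which 1 of the 3 values shown sits.

The compounds shown leave open whether compound 2 truly differs from compound 1 and compound 3 by more than the scatter, since the real value of compound 2 lies beyond what this test reads. They also leave open whether a group of another kind on this aromatic carbon, such as an amine or a carboxylic acid, would give a step beyond the scatter, or whether the three groups shown simply all sit in the same narrow range at the top of this test.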